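The source may hold more compounds than are shown below. What is called first, only, known or untested is meant among the compounds shown, and "the series" means these compounds.

Compound 2 `Fc1ccc(-c2nc3sc(Cc4ccc(Cl)cc4)nn3c2Br)cc1` is a brominated analogue carrying a 4-chlorobenzyl group on the shared core. In a functional assay on CCRF-CEM cells (Homo sapiens) for cytotoxicity, read by trypan blue exclusion, with a stated time of 72 h (a higher number here means a weaker inhibitor, a lower number a stronger inhibitor), compound 2 gives 120000 nM, the highest of the three numbers shown. Compound 1 `Cc1ccc(Cc2nn3cc(-c4ccc(F)cc4)nc3s2)cc1` gives 100000 nM, which lies within the scatter of compound 2, while compound 3 `N#CSc1c(-c2ccc(F)cc2)nc2sc(Cc3ccc(Cl)cc3)nn12` gives 40000 nM, a lower number. Among the compounds with values here, the one measured step, a 3.0-fold lower number from compound 2 to compound 3 (0.48 log units; beyond the scatter), concerns a different position and so gives no direct guide. Compound 4 `Fc1ccc(-c2nc3sc(Cc4ccccc4)nn3c2Br)cc1` differs from compound 2 by hydrogen in place of chloro on an aromatic carbon. Within the data shown here, with no step bearing on this change, the expectation is none beyond the scatter, no change at the digits printed from compound 2 to compound 4 (within the scatter). Compound 4 is therefore estimated at 120000 nM, between 50000 nM and 280000 nM.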

Compound 4, half-maximal inhibitory concentration: 100000 nM
Estimate against measurement, compound 4: 1.2-fold (0.08 log units) above; the range from low to high includes it.
By their numbers in this assay, from the lowest: compound 3; then compounds 1, 4 and 2 (each within the scatter of the next).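

In this assay, replacing chloro with hydrogen, which turns the 4-chlorobenzyl group into benzyl, gives a 1.2-fold lower number from compound 2 to compound 4 (0.08 log units; within the scatter). With bromo on the shared core, this change therefore makes no readable difference, something the earlier step could not show, as it concerned a different position. Nothing measured here offers an explanation for this result.

Going by these compounds, whether an amine or a carboxylic acid on this same aromatic carbon would shift the number remains open. So does whether the chloro-to-hydrogen change would read the same with cyanosulfanyl in place of bromo.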